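Nitrophenyl swap from compound 3 to compound 4

A few compounds are considered here, and "the series" means these few. Any claim that something is new, unique, unknown or untested is made for them only; others in the source may bear on it.

Values in a functional assay on HeLa cells (Homo sapiens) for cytotoxicity, read by MTT assay, with a stated time of 24 h (on this read-out higher numbers stand for weaker inhibition and lower numbers for stronger inhibition), so far:
compound 1 `C/C(=N\NC(=O)/C(C#N)=C/c1ccc(Br)cc1)c1c(O)c2ccc(O)cc2oc1=O` gives 10600 nM
compound 2 `C/C(=N\NC(=O)/C(C#N)=C/c1ccc(N(C)C)cc1)c1c(O)c2ccc(O)cc2oc1=O` gives 5140 nM
compound 3 `C/C(=N\NC(=O)/C(C#N)=C/c1cccc([N+](=O)[O-])c1)c1c(O)c2ccc(O)cc2oc1=O` gives 24600 nM

The highest number of the three belongs to compound 3. The steps reaching it are modest but beyond the scatter: a 2.3-fold higher number from compound 1 to compound 3 (0.37 log units; beyond the scatter) and a 4.8-fold higher number from compound 2 to compound 3 (0.68 log units; beyond the scatter) on this read-out. Unmeasured compound 4 `C/C(=N\NC(=O)/C(C#N)=C/c1ccc([N+](=O)[O-])cc1)c1c(O)c2ccc(O)cc2oc1=O` carries 4-nitrophenyl in place of 3-nitrophenyl on a double-bonded chain carbon bound to a double-bonded chain carbon. Going by the values given here, no measured step isolates this swap. The closest evidence is indirect: both 4-substituted compounds have lower numbers than compound 3, but the group differs as well, and a 2.1-fold lower number from compound 1 to compound 2 (0.31 log units; beyond the scatter) shows that the number moves with the group. A slight drift to a lower number is expected, with no firm step beyond the scatter, and the estimated change is a 1.8-fold lower number from compound 3 to compound 4 (0.24 log units; within the scatter) in this assay overall. The estimated value for compound 4 is 14000 nM (expected range 6000 nM to 32000 nM).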

Compound 4, half-maximal inhibitory concentration: 8360 nM
The estimate for compound 4 lay 1.7-fold (0.22 log units) above the measured number; the measured number falls inside the stated range.
By their numbers in this assay, from the lowest: compounds 2, 4 and 1 (each within the scatter of the next, the first and the last beyond it); then compound 3.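

Going by these compounds alone, with the nitro group held constant, the change from 3-nitrophenyl to 4-nitrophenyl alone gives a 2.9-fold lower number from compound 3 to compound 4 (0.47 log units; beyond the scatter) in this assay, the first measured step that isolates the placement of a group from its identity. Among the compounds with a 4-substituted phenyl, nitro does not separate from the other groups, with a 1.6-fold higher number from compound 2 to compound 4 (0.21 log units; within the scatter) and a 1.3-fold lower number from compound 1 to compound 4 (0.10 log units; within the scatter), although dimethylamino and bromo remain apart at a 2.1-fold lower number from compound 1 to compound 2 (0.31 log units; beyond the scatter). Nothing measured here bears on what lies behind these differences.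

Within the data shown here, compound 3 is the only compound with its group in the 3-nitrophenyl arrangement, so it remains open whether 3-bromophenyl or 3-(dimethylamino)phenyl would differ from their 4-substituted counterparts in the same way. Also open, from the compounds shown here alone, is where unsubstituted phenyl or a phenyl bearing a carboxylic acid would fall.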